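Swapping the Configuration at a Chain Carbon

This account rests on a few compounds, and the source may have more. Where it says the series, first, only, none or still open, it means among the compounds named here.

Measured compounds:
compound 1, `COc1ccc(C(C)NC(=O)/N=C(\N)NCCCc2sc(N)nc2C)cc1`: 37.2 nM
compound 2, `Cc1nc(N)sc1CCCN/C(N)=N/C(=O)N[C@H](C)c1ccccc1`: 17.8 nM

In an assay on membranes from Sf9 cells for displacement of a labelled ligand from histamine H2 receptor (Homo sapiens), read by scintillation counting, with a stated time of 60 min (on this read-out lower numbers stand for stronger inhibition and higher numbers for weaker inhibition), compound 1 gives 37.2 nM, and compound 2 gives 17.8 nM. Of these two numbers, compound 2 holds the lower one, and the gap to compound 1 lies beyond the usual scatter of repeated measurements. Among the measured compounds shown here, the two measured compounds differ in more than one place, so no single structural step between them can be read off.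

The compound not yet measured, compound 3 `Cc1nc(N)sc1CCCN/C(N)=N/C(=O)N[C@@H](C)c1ccccc1`, is built from compound 2 by one change: the two compounds have the same atoms and bonds and differ only in configuration as drawn: 1 of 2 stereo elements differ; a stereocentre at a saturated chain carbon is drawn R in compound 2 and S in compound 3. Nothing is added and nothing is taken away; only the spatial arrangement at that one carbon is reversed. For the measured compounds named here, no measured pair in this set shows what such a reversal does here, so the direction of the step in this assay can only be guessed. Because compound 2 gives 17.8 nM, the lowest number seen, the step from compound 2 to compound 3 is expected to be a 2.2-fold higher number from compound 2 to compound 3 (0.35 log units; beyond the scatter), pointing toward a weaker number. Compound 3 is expected to give 40 nM, in a range from 12 nM to 150 nM.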

Compound 3, inhibition constant: 51.3 nM
Beside the measured number, compound 3's estimate is 1.3-fold (0.11 log units) below it; the measured number falls inside the stated range.
By their numbers in this assay, from the lowest: compound 2; then compounds 1 and 3 (each within the scatter of the next).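

In this assay the configuration at this saturated chain carbon clearly counts, and the R form is the favoured one: there is a 2.9-fold higher number from compound 2 to compound 3 (0.46 log units; beyond the scatter) in this pair. Among the compounds shown here, this is the first pair in the set that isolates a single change, and the gap can be laid on the reversal at that one carbon alone, because nothing else separates the two structures: the fact that compounds 2 and 3 differ only in the configuration as drawn. The reversal weakens the number without abolishing it, since compound 3 still gives 51.3 nM in this assay, so the position responds to spatial arrangement even when no atom is added or removed.

As far as these compounds go, it remains open whether the preference for the R form would hold with another group at that carbon, such as an ethyl group or a hydroxyl group, and whether the gap would then widen, narrow or turn around. For the compounds shown here, the numbers also show only that the reading shifts with the reversal, and they give no account of what the change does at the receptor.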